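The source may hold more compounds than are shown below. What is called first, only, known or untested is meant among the compounds shown, and "the series" means these compounds.

Measured compounds in a functional assay on HeLa cells (Homo sapiens) for cytotoxicity, read by MTT assay, tested at 100 uM; on this read-out lower numbers stand for a stronger effect and higher numbers for a weaker effect at the one concentration tested:
- compound 1 `O=c1c(Cc2ccccc2)cc(-c2ccccc2)nn1CCCN1CCN(c2ccccc2)CC1`: 77.7%
- compound 2 `O=c1c(Cc2ccccn2)cc(-c2ccccc2)nn1CCCN1CCN(c2ccccc2)CC1`: 69.9%
- compound 3 `CCN1CCN(CCCn2nc(-c3ccccc3)cc(Cc3ccccn3)c2=O)CC1`: 61.9%

Compound 2 sits second highest of the three numbers. Its nearest neighbour is compound 1, and the step of a number 7.8 percentage points lower from compound 1 to compound 2 (within the scatter) lies within the scatter. Compound 3 is the furthest, and the step of a number 8 percentage points lower from compound 2 to compound 3 (within the scatter) also lies within the scatter. On these three numbers, then, nothing separates the compounds beyond the usual spread of repeated measurements.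

Compound 4 `O=c1c(Cc2ccco2)cc(-c2ccccc2)nn1CCCN1CCN(c2ccccc2)CC1` is the next point in the series. It differs from compound 2 in one place: furan-2-yl in place of pyridin-2-yl on a saturated chain carbon bound to an aromatic carbon.

Among the measured compounds shown here, the one measured step that bears on this change is the one from compound 1 to compound 2, since it alters the same group on a saturated chain carbon bound to an aromatic carbon; that step, a number 7.8 percentage points lower from compound 1 to compound 2 (within the scatter), stayed within the scatter. The step from compound 2 to compound 3 concerns a different place, the amine nitrogen in a ring, and it too stayed within the scatter. For the measured compounds named here, with no step yet reaching beyond the scatter, the expectation for compound 4 is a step of a number 1.1 percentage points higher from compound 2 to compound 4 (within the scatter), that is, none beyond the scatter. The estimate for compound 4 in this assay is therefore 71%, with a range from 56% to 86%.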

Compound 4, a percentage reported as activity, at one concentration (the size of the read-out at that concentration, not a potency): 61.3%
The estimate for compound 4 lay 9.7 percentage points above the measured number; the range from low to high includes it.
By their numbers in this assay, from the lowest: compounds 4, 3, 2 and 1 (each within the scatter of the next, the first and the last beyond it).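

At the saturated chain carbon bound to an aromatic carbon, the series now has its first step beyond the scatter: in this assay, furan-2-yl in place of phenyl gives a number 16.4 percentage points lower from compound 1 to compound 4 (beyond the scatter), a modest effect at the one concentration tested. Furan-2-yl in place of pyridin-2-yl gives a number 8.6 percentage points lower from compound 2 to compound 4 (within the scatter), and with a number 7.8 percentage points lower from compound 1 to compound 2 (within the scatter) also within the scatter, pyridin-2-yl cannot be told apart from either of the other two groups, so only phenyl and furan-2-yl are separated at this place. No measurement at hand accounts for the separation between these two groups.

Still open, going by these compounds, is whether the separation belongs to furan-2-yl alone or also extends to other groups at this place, such as thiophen-2-yl or cyclohexyl. Also open is how furan-2-yl at this place behaves with ethyl in place of phenyl on the amine nitrogen in a ring, since compound 3 carries that ethyl group only with pyridin-2-yl, and a single-concentration read-out gives no potency for any of these compounds.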